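Notes on the benzylamino-to-amino step in the series

The source may hold more compounds than are shown below. What is called first, only, known or untested is meant among the compounds shown, and "the series" means these compounds.

Among the measured compounds shown here, compound 2 `CCCCC[Se]c1nc(NCc2ccccc2)c2ccccc2n1` is the only member with a measured number: in a functional assay on HTB-54 cells (Homo sapiens) for cytotoxicity, read by MTT assay, with a stated time of 72 h (on this read-out higher numbers stand for weaker inhibition of growth and lower numbers for stronger inhibition of growth), compound 2 gives 81100 nM. Compound 1 `CCCCC[Se]c1nc([Se]CCCCC)c2ccccc2n1` reaches only a limit, > 100000 nM, as set out in the limit of > 100000 nM in this assay, at which 1 of the 2 values shown sits. For the measured compounds named here, the one measured step, an at least 1.2-fold lower number from compound 1 to compound 2 (0.09 log units; that floor lies within the scatter), exchanges a group on an aromatic carbon and sits within the scatter. Compound 3 `CCCCC[Se]c1nc(N)c2ccccc2n1` differs from compound 2 by hydrogen in place of benzyl on a nitrogen on an aromatic ring. Going by the values given here, no measured step touches this nitrogen, and the single known step is both within the scatter and at another place, so it supplies no direction for the change. With compound 2 already close to the limit of this assay, the expected step of a 1.1-fold higher number from compound 2 to compound 3 (0.05 log units; within the scatter) is none beyond the scatter, and a limit rather than a number is about as likely as not. Compound 3 is estimated at 90000 nM, within 35000 nM to 230000 nM.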

Compound 3, concentration for total growth inhibition: 84000 nM
Compound 3: middle estimate off by 1.1-fold (0.03 log units), on the high side; measured number inside the range.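

In this assay, among the compounds shown here, the first measured step at this nitrogen lies within the scatter: a 1.0-fold higher number from compound 2 to compound 3 (0.02 log units; within the scatter). Benzylamino and amino therefore cannot be told apart on this read-out, and the benzyl group with its six-membered aromatic ring carries no readable weight at this place in the shared core. The other new step, an at least 1.1-fold lower number from compound 1 to compound 3 (0.07 log units; that floor lies within the scatter), starts from a limit of the assay and gives no size: the limit of > 100000 nM in this assay, at which 1 of the 3 values shown sits.

Open, going by these compounds, is whether any other group on this nitrogen, such as a longer alkyl chain or a chain ending in a carboxylic acid, would give a step beyond the scatter. Also open is whether a longer chain on the selenium would do so, as all the numbers shown so far stand close together.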